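Adding a methyl to the urea side chain in compound 3

The source may report more compounds than this note shows. Statements on the series, on what has been measured and on what is new or still open speak of the compounds shown alone.

Compound 1 `CC(C)NC(=O)N1CCN(C(=S)SCc2cn(Cc3ccccc3F)nn2)CC1` gives 7130 nM in a functional assay on SMMC-7721 cells (Homo sapiens) for cytotoxicity, read by MTT assay, with a stated time of 72 h; on this read-out lower numbers stand for stronger inhibition and higher numbers for weaker inhibition. Compound 2 `NC(=O)N1CCN(C(=S)SCc2cn(Cc3ccc(F)cc3)nn2)CC1` reaches only the limit of this assay, > 128000 nM. Compound 3 `CCNC(=O)N1CCN(C(=S)SCc2cn(Cc3ccc(F)cc3)nn2)CC1` gives 44400 nM, the highest of the two numbers shown; the nearest is compound 1, whose number is lower. Going by the values given here, the one measured step, an at least 2.8-fold lower number from compound 2 to compound 3 (0.45 log units; beyond the scatter), lowered the number. Compound 4 `CC(C)NC(=O)N1CCN(C(=S)SCc2cn(Cc3ccc(F)cc3)nn2)CC1` differs from compound 3 by methyl in place of hydrogen on a saturated chain carbon bound to an amide-type nitrogen and a saturated chain carbon. Compound 1 carries the same isopropyl group but differs elsewhere, so only its value can be set beside that of compound 3. Since the step from compound 2 to compound 3 lowered the number, a further lowering is expected, and for compound 4 an estimated 15000 nM, between 5000 nM and 45000 nM, with the expected step of a 3.0-fold lower number from compound 3 to compound 4 (0.47 log units; beyond the scatter).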

Compound 4, half-maximal inhibitory concentration: 5970 nM
Beside the measured number, compound 4's estimate is 2.5-fold (0.40 log units) above it; measured number inside the range.
By their numbers in this assay, from the lowest: compounds 4 and 1 (each within the scatter of the next); then compound 3. At a limit, above all of these: compound 2.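

Turning ethyl into isopropyl gives a 7.4-fold lower number from compound 3 to compound 4 (0.87 log units; beyond the scatter), so a single added methyl on this side chain still moves the number clearly, and the whole change from hydrogen to isopropyl amounts to an at least 21-fold lower number from compound 2 to compound 4 (1.33 log units; beyond the scatter). Compound 2 stands at a limit, not at a number: the limit of > 128000 nM in this assay, at which 1 of the 4 values shown sits. With isopropyl on the urea, 4-fluorophenyl in place of 2-fluorophenyl gives a 1.2-fold lower number from compound 1 to compound 4 (0.08 log units; within the scatter), so these two fluorine placements cannot be told apart here. Still open, on these data alone, is whether a straight propyl chain, a tert-butyl group or a cyclohexyl ring on this urea nitrogen would lower the number further or raise it again.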